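Replacing the Basic Amide Substituent with a Hydroxyalkyl Group

The compounds below may be only part of what the source reports. "The series", "measured", "known", "first", "only" and "open" are said of these compounds alone.

Measured compounds:
Compound 1, `CCn1c(C(=O)NCCCN(C)C)ccc1C(CC)(CC)c1ccc(OCCC(O)(CC)CC)c(C)c1`: 5 nM
Compound 2, `C#CCCOC(=O)c1ccc(C(CC)(CC)c2ccc(OCCC(O)(CC)CC)c(C)c2)n1CC`: 6030 nM
Compound 3, `CCOc1ccc(NC(=O)c2ccc(C(CC)(CC)c3ccc(OCCC(O)(CC)CC)c(C)c3)n2CC)cc1`: 1630 nM

In an assay on cells for agonist activity at vitamin D3 receptor (Homo sapiens), with a stated time of 96 h (on this read-out higher numbers stand for an effect only at larger amounts of compound and lower numbers for an effect already at smaller amounts), compound 1 gives the lowest of the three numbers. Its nearest neighbour is compound 3, and a 330-fold higher number from compound 1 to compound 3 (2.51 log units; beyond the scatter); the furthest is compound 2, and a 1200-fold higher number from compound 1 to compound 2 (3.08 log units; beyond the scatter). Between the two weaker compounds, a 3.7-fold lower number from compound 2 to compound 3 (0.57 log units; beyond the scatter).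

Compound 4, `CCn1c(C(=O)NC(C)CO)ccc1C(CC)(CC)c1ccc(OCCC(O)(CC)CC)c(C)c1`, has not yet been measured. It differs from compound 1 in one place: 1-(hydroxymethyl)ethyl in place of 3-(dimethylamino)propyl on an amide-type nitrogen. Both measured steps that start from compound 1 exchange the (3-(dimethylamino)propyl)carbamoyl group, and both are large losses, so they bear on this change; yet in compound 4 the carbamoyl nitrogen keeps an open-chain, non-aromatic substituent carrying one hydrogen-bond donor and one acceptor, which neither compound 2 nor compound 3 does. The expected step is therefore a loss, but a far smaller one than a 330-fold higher number from compound 1 to compound 3 (2.51 log units; beyond the scatter); compound 4 is expected to show a 5.0-fold higher number from compound 1 to compound 4 (0.70 log units; beyond the scatter). Compound 4 is estimated at 25 nM, within 5 nM to 150 nM.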

Compound 4, half-maximal effective concentration: 96 nM
The estimate for compound 4 lay 3.8-fold (0.58 log units) below the measured number, within the range that was stated.
By their numbers in this assay, from the lowest: compound 1; then compound 4; then compound 3; then compound 2.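

In this assay, the (3-(dimethylamino)propyl)carbamoyl group of compound 1 could not be exchanged without a clear cost, even for an open-chain group on the amide-type nitrogen (a 19-fold higher number from compound 1 to compound 4 (1.28 log units; beyond the scatter)). Still, the 1-(hydroxymethyl)ethyl group retained far more than either earlier replacement (a 17-fold lower number from compound 3 to compound 4 (1.23 log units; beyond the scatter); a 63-fold lower number from compound 2 to compound 4 (1.80 log units; beyond the scatter)), so the loss at this position depended strongly on what replaced the group. No measurement on hand accounts for these differences.

Which feature of the 1-(hydroxymethyl)ethyl group sets the result remains open, whether its hydroxyl or its methyl branch. Also open, from the compounds shown here alone, is whether an unbranched hydroxypropyl chain, a primary amine on a propyl chain, or a longer chain ending in dimethylamino would come closer to compound 1.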